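The source may hold more compounds than are shown below. What is called first, only, known or untested is meant among the compounds shown, and "the series" means these compounds.

In a functional assay on BGC-823 cells (Homo sapiens) for antiproliferative activity, read by MTT assay, with a stated time of 48 h (a higher number here means a weaker inhibitor, a lower number a stronger inhibitor), three compounds have been measured so far:

compound 1 `CCn1cc(-c2ccc(Cl)cc2)c(=O)c2cc(F)c(N3CCNCC3)cc21` gives 14600 nM
compound 2 `CCn1cc(-c2ccc(OC)cc2)c(=O)c2cc(F)c(N3CCNCC3)cc21` gives 46100 nM
compound 3 `CN1CCN(c2cc3c(cc2F)c(=O)c(-c2cccc(Cl)c2)cn3C2CC2)CC1` gives 20200 nM

Compound 1 and compound 2 differ in one place, namely (methoxy in place of chloro on an aromatic carbon), and in this assay that change made a step of a 3.2-fold higher number from compound 1 to compound 2 (0.50 log units; beyond the scatter). Compound 3 is built on a different core from compound 1; the difference between the two cores is not broken down here. In this assay compound 3 and compound 1 stand within the scatter of each other, whereas the gap between compound 3 and compound 2 lies beyond it.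

Compound 4 `COc1cccc(-c2cn(C3CC3)c3cc(N4CCN(C)CC4)c(F)cc3c2=O)c1` has not yet been measured in this assay. It differs from compound 3 by methoxy in place of chloro on an aromatic carbon. For the measured compounds named here, this is the same kind of change as the one from compound 1 to compound 2, but not the same: in compound 2 the methoxy sits para to a large group, in compound 4 it sits meta to a large group.

Because the earlier change gave a 3.2-fold higher number from compound 1 to compound 2 (0.50 log units; beyond the scatter), compound 4 is expected to give a higher number than compound 3, by a step estimated at a 2.7-fold higher number from compound 3 to compound 4 (0.44 log units; beyond the scatter). The estimate for compound 4 in this assay is 55000 nM, expected to fall between 20000 nM and 150000 nM.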

Compound 4, half-maximal inhibitory concentration: 20900 nM
Estimate against measurement, compound 4: 2.6-fold (0.42 log units) above; low and high end bracket the measured number.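

In this assay, methoxy in place of chloro on an aromatic carbon gave a 1.0-fold higher number from compound 3 to compound 4 (0.01 log units; within the scatter), so on the core of compound 3 the change from 3-chlorophenyl to 3-methoxyphenyl made a step that lies within the scatter. Set beside the earlier step, the same kind of change did not carry over in size from one core to the other: the same change on two cores in this assay, a 3.2-fold higher number (0.50 log units; beyond the scatter) from compound 1 to compound 2 and a 1.0-fold higher number (0.01 log units; within the scatter) from compound 3 to compound 4, 3.1-fold (0.48 log units) apart, beyond the scatter of two such steps. What lies behind this gap is not shown: the two pairs differ both in the core and in where the methoxy sits, and a single pair on each core cannot separate the two.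

The compounds shown leave open how chloro and methoxy compare when both sit at one and the same place on each of the two cores. They also leave open how other groups at that place, such as an amine or a carboxylic acid, would stand against chloro and methoxy on either core.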